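The source may report more compounds than this note shows. Statements on the series, on what has been measured and on what is new or still open speak of the compounds shown alone.

Compound 1 `CC(=O)Nc1cc(-c2ccc(N(C)C(=O)c3c(F)cccc3Cl)c(N3CCCCC3)c2)n(C(C)C)n1`; in an ADME assay on a cell-free system (plasma, Rattus norvegicus) (on this read-out higher numbers stand for a larger free fraction and lower numbers for a smaller free fraction), compound 1 gives 0.001.
Compound 2 `CC(=O)Nc1cc(-c2ccc(N(C)C(=O)c3c(F)cccc3Cl)c(OCC(C)C)c2)n(C(C)C)n1`; in this assay compound 2 gives 0.002.
Compound 3 `CC(=O)Nc1cc(-c2ccc(N(C)C(=O)c3c(Cl)cccc3Cl)c(N3CC4CC4C3)c2)n(C(C)C)n1`; in this assay compound 3 gives 0.001.

Compound 2 stands no further from compound 1 or from compound 3 than the usual scatter of such measurements, so the three cannot be told apart on these numbers. Compound 4 `CC(=O)Nc1cc(-c2ccc(N(C)C(=O)c3c(F)cccc3Cl)c(N3CCCC3)c2)n(C(C)C)n1` differs from compound 2 by pyrrolidin-1-yl in place of isobutoxy on an aromatic carbon. For the measured compounds named here, the only measured step that bears on this exchange is the one between compound 1 and compound 2, where isobutoxy replaced piperidin-1-yl and gave a 2.0-fold higher number from compound 1 to compound 2 (0.30 log units; within the scatter). Compound 4 reverses that kind of exchange, so a step of similar size in the opposite direction, still within the scatter, is expected, a 1.3-fold lower number from compound 2 to compound 4 (0.12 log units; within the scatter). Compound 4 is therefore estimated at 0.0015, with a range from 0.0007 to 0.003.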

Compound 4, unbound fraction: 0.009
Beside the measured number, compound 4's estimate is 6.0-fold (0.78 log units) below it, outside the stated range (above it).
By their numbers in this assay, from the lowest: compounds 1, 3 and 2 (each within the scatter of the next); then compound 4.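

Placing pyrrolidin-1-yl on this aromatic carbon gives a 4.5-fold higher number from compound 2 to compound 4 (0.65 log units; beyond the scatter) and a 9.0-fold higher number from compound 1 to compound 4 (0.95 log units; beyond the scatter) in this assay, so this position can shift the free fraction beyond the scatter, which the earlier compounds did not show. Among these three groups the shift is confined to pyrrolidin-1-yl, since isobutoxy, with the same heavy-atom count, and piperidin-1-yl, also a non-aromatic ring, remain within the scatter of each other. No evidence here accounts for this difference. Going by these compounds, it remains open whether azetidin-1-yl, morpholin-4-yl or dimethylamino at this carbon would follow pyrrolidin-1-yl or stay with piperidin-1-yl.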